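The source may report more compounds than this note shows. Statements on the series, on what has been measured and on what is new or still open speak of the compounds shown alone.

Measured compounds in an ADME assay on L02 cells (Homo sapiens) for antiproliferative activity, read by MTT assay, with a stated time of 48 h; on this read-out lower numbers stand for stronger inhibition and higher numbers for weaker inhibition:
compound 1 `CCc1ccccc1-n1nncc1CN1C(=O)C2(C(C#N)=C(N)Oc3c(N)cc4nc5ccccc5nc4c32)c2ccccc21` gives 22900 nM.
compound 2 `N#CC1=C(N)Oc2c(N)cc3nc4ccccc4nc3c2C12C(=O)N(Cc1cnnn1-c1ccccc1Br)c1ccccc12` gives 29200 nM.
compound 3 `COc1ccc(-n2nncc2CN2C(=O)C3(C(C#N)=C(N)Oc4c(N)cc5nc6ccccc6nc5c43)c3ccccc32)cc1` reaches only > 50000 nM, which is a limit of the assay and not a number.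

Compound 3 therefore stands at the boundary described by the limit of > 50000 nM in this assay, at which 1 of the 3 values shown sits. The change to compound 4 `Cc1cc(C)cc(-n2nncc2CN2C(=O)C3(C(C#N)=C(N)Oc4c(N)cc5nc6ccccc6nc5c43)c3ccccc32)c1` is 3,5-dimethylphenyl in place of 4-methoxyphenyl on an aromatic nitrogen. Two measured steps alter the same aryl group on that ring nitrogen: an at least 2.1-fold higher number from compound 1 to compound 3 (0.33 log units; beyond the scatter) and an at least 1.7-fold higher number from compound 2 to compound 3 (0.23 log units; that floor lies within the scatter), both ending at the limit once 4-methoxyphenyl enters. Compound 4 removes that 4-methoxyphenyl again. In this assay a modest move back from the limit is expected for compound 4, as an at least 1.2-fold lower number from compound 3 to compound 4 (0.09 log units; that floor lies within the scatter). Compound 4 is thus estimated at 40000 nM, between 18000 nM and 90000 nM, with a fair chance that only a limit is reported.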

Compound 4, half-maximal inhibitory concentration: > 50000 nM
Compound 4: only a limit was reported (the forecaster's own chance of this, stated with the estimate: 45%); middle value at least 1.2-fold (0.09 log units) away from the limit.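

In this assay compound 4 is reported only as a limit, the same kind of result as for compound 3: the limit of > 50000 nM in this assay, at which 2 of the 4 values shown sit. The limit is therefore not confined to 4-methoxyphenyl on this aromatic nitrogen: 3,5-dimethylphenyl, which has no hydrogen-bond acceptor, also ends there, giving an at least 2.1-fold higher number from compound 1 to compound 4 (0.33 log units; beyond the scatter) and an at least 1.7-fold higher number from compound 2 to compound 4 (0.23 log units; that floor lies within the scatter). The step between compound 3 and compound 4, both limits, cannot be read.

As far as these compounds go, how far compound 3 and compound 4 lie past the limit remains open. So does how a phenyl carrying an amine or a carboxylic acid would read on this nitrogen.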